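The source may hold more compounds than are shown below. What is called first, only, known or untested is meant among the compounds shown, and "the series" means these compounds.

Compound 1 `COc1cccc(/C=C2\CCC/C(=C\c3ccccc3Cl)C2=O)c1OC`: 44200 nM
Compound 2 `COc1cccc(/C=C2\CCC/C(=C\c3ccccc3Br)C2=O)c1OC`: > 50000 nM
Compound 3 `COc1cccc(/C=C2\CCC/C(=C\c3cccc(Br)c3)C2=O)c1OC`: 23900 nM

All three values come from an ADME assay on NHDF cells (Homo sapiens) for cytotoxicity, read by MTT assay, with a stated time of 72 h; a higher number here means a weaker inhibitor, a lower number a stronger inhibitor. Compound 2 gives > 50000 nM, which is a limit of the assay and not a number. Its place on the scale is therefore only (the limit of > 50000 nM in this assay, at which 1 of the 3 values shown sits).

Compound 4 `COc1ccccc1/C=C1\CCC/C(=C\c2cccc(OC)c2OC)C1=O` has not yet been measured. Its difference from compound 2 is methoxy in place of bromo on an aromatic carbon, ortho to a large group, so 2-bromophenyl becomes 2-methoxyphenyl: methoxy in place of bromo on an aromatic carbon.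

Among the compounds with values here, no measured step makes this exact exchange. The closest is the swap of bromo for chloro, an at least 1.1-fold higher number from compound 1 to compound 2 (0.05 log units; that floor lies within the scatter), which shows no change beyond the scatter. The step to the 3-bromophenyl compound is larger, an at least 2.0-fold lower number from compound 2 to compound 3 (0.32 log units; beyond the scatter), while a 1.8-fold lower number from compound 1 to compound 3 (0.27 log units; within the scatter) stays within the scatter. Those two steps alter where the group sits, and compound 4 keeps the arrangement of compound 2, so they bear on it less directly.

In this assay, no step beyond the scatter is therefore expected, and another limit is quite possible. The expected step is an at least 1.1-fold lower number from compound 2 to compound 4 (0.07 log units; that floor lies within the scatter). For compound 4 the estimated value is 42000 nM, with an expected range of 22000 nM to 70000 nM.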

Compound 4, half-maximal inhibitory concentration: 31300 nM
The estimate for compound 4 lay 1.3-fold (0.13 log units) above the measured number; the range from low to high includes it.
By their numbers in this assay, from the lowest: compounds 3, 4 and 1 (each within the scatter of the next). At a limit, above all of these: compound 2.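

Compound 2 stands at a limit of the assay and not at a number: the limit of > 50000 nM in this assay, at which 1 of the 4 values shown sits.

In this assay, methoxy in place of bromo on this aromatic carbon, ortho to a large group, gives a reading on the measurable scale, with an at least 1.5-fold lower number from compound 2 to compound 4 (0.20 log units; that floor lies within the scatter), so only a floor on the size of this change is known. The two other comparisons do not separate the new compound from its neighbours: a 1.4-fold lower number from compound 1 to compound 4 (0.15 log units; within the scatter), and a 1.3-fold higher number from compound 3 to compound 4 (0.12 log units; within the scatter). Methoxy at this position therefore gives a reading that cannot be told apart from those of the chloro compound and the 3-bromophenyl compound, and the only compound that stands out is the one held at the limit.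

The compounds shown carry only chloro, bromo or methoxy on this ring, so it remains open whether an amine or a carboxylic acid at this position would give a reading in the same range. As far as these compounds go, it also remains open how a longer chain, such as ethoxy in place of methoxy, would read, and how far the true value of compound 2 lies from the others.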